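Swapping the Ether Link for an Amine Link

A few compounds are considered here, and "the series" means these few. Any claim that something is new, unique, unknown or untested is made for them only; others in the source may bear on it.

Among the measured compounds shown here, in a functional assay on HEK293 cells for antagonist activity at thromboxane A2 receptor (Homo sapiens), read by fluorescence and calcium flux (on this read-out higher numbers stand for weaker inhibition and lower numbers for stronger inhibition), compound 1 `CC(C)NC(=O)NS(=O)(=O)c1cc(C#N)ccc1Oc1ccc(Cl)cc1` gives 9460 nM, the top of the two numbers measured so far. Compound 2 `CC(C)(C)NC(=O)NS(=O)(=O)c1cc(C#N)ccc1Oc1ccc(Cl)cc1` gives 5640 nM, and the step of a 1.7-fold lower number from compound 1 to compound 2 (0.22 log units; within the scatter) changes the methyl count on the chain carbon bound to the urea nitrogen. Compound 3 `Cc1cccc(Nc2ccc(C#N)cc2S(=O)(=O)NC(=O)NC(C)C)c1` differs from compound 1 by (3-methylphenyl)amino in place of 4-chlorophenoxy on an aromatic carbon. For the measured compounds named here, the one measured step concerns a different part of the molecule and says nothing about this exchange, so no direction can be drawn from it. The estimate for compound 3 is 6000 nM, with a range from 1500 nM to 25000 nM. The step expected is a 1.6-fold lower number from compound 1 to compound 3 (0.20 log units; within the scatter).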

Compound 3, half-maximal inhibitory concentration: 9500 nM
For compound 3 the middle estimate is 1.6-fold (0.20 log units) below the measured one, within the range that was stated.
By their numbers in this assay, from the lowest: compounds 2, 1 and 3 (each within the scatter of the next).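

In this assay, (3-methylphenyl)amino in place of 4-chlorophenoxy, on the aromatic carbon para to a cyano group, gives a 1.0-fold higher number from compound 1 to compound 3 (0.00 log units; within the scatter) and so leaves the number where it was. This one exchange alters both the link to the ring, which gains a hydrogen-bond donor, and the group on that ring, yet no shift beyond the scatter appears. Nothing measured here offers an explanation for this result.

On these data alone, it remains open whether the new link and the new ring group each matter alone and cancel out. A carboxylic acid or an amine on that ring might also move the number beyond the scatter.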